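Tert-butyl in place of methyl on the ester of compound 3

The compounds below may be only part of what the source reports. "The series", "measured", "known", "first", "only" and "open" are said of these compounds alone.

In a toxicity assay on HEK-293T cells (Homo sapiens) for cytotoxicity, read by MTT assay, with a stated time of 48 h (on this read-out higher numbers stand for weaker inhibition and lower numbers for stronger inhibition), compound 1 `C=C1[C@H](OC(C)=O)[C@@H](OC(=O)C(C)(C)C)[C@@H](OC(C)=O)C(C)(C)/C=C/[C@H](C)[C@H](OC(=O)c2ccccc2)[C@@]2(O)C[C@@](C)(OC(C)=O)[C@H](OC(C)=O)[C@@H]2[C@H]1OCC(C)C` gives 18900 nM and compound 2 `C=C1[C@H](OC(C)=O)[C@@H](OC(C)=O)[C@@H](OC(C)=O)C(C)(C)/C=C/[C@H](C)[C@H](OC(=O)c2ccccc2)[C@@]2(O)C[C@@](C)(OC(=O)c3ccncc3)[C@H](OC(C)=O)[C@@H]2[C@H]1OCC(C)C` gives 19500 nM while compound 3 `C=C1[C@H](OC(C)=O)[C@@H](OC(C)=O)[C@@H](OC(C)=O)C(C)(C)/C=C/[C@H](C)[C@H]2O[C@]3(C)C[C@@]2(OC(=O)c2ccccc2)[C@H]([C@H]3OC(C)=O)[C@H]1OCC(C)C` gives 13500 nM as a value within the usual scatter of both others. Compound 4 `C=C1[C@H](OC(C)=O)[C@@H](OC(=O)C(C)(C)C)[C@@H](OC(C)=O)C(C)(C)/C=C/[C@H](C)[C@H]2O[C@]3(C)C[C@@]2(OC(=O)c2ccccc2)[C@H]([C@H]3OC(C)=O)[C@H]1OCC(C)C` departs from compound 3 by one change tert-butyl in place of methyl on a carbonyl carbon which puts tert-butyl in place of methyl on a carbonyl carbon. Going by the values given here, no measured pair isolates this change. Compound 1 also carries (tert-butyl)carbonyl and gives 18900 nM within the scatter of compound 3 as well. In this assay no step beyond the scatter is expected, and the estimated step is a 1.1-fold higher number from compound 3 to compound 4 (0.05 log units; within the scatter) in size. For compound 4 the estimated value is 15000 nM within an expected range of 9000 nM to 25000 nM on this read-out.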

Compound 4, half-maximal inhibitory concentration: > 100000 nM
Compound 4 gave a limit, no number; the forecaster's own chance of this, stated with the estimate: 5%; middle value at least 6.6-fold (0.82 log units) from the limit.
By their numbers in this assay, from the lowest: compounds 3, 1 and 2 (each within the scatter of the next). At a limit, above all of these: compound 4.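

In this assay, tert-butyl in place of methyl on a carbonyl carbon is the only single change shown, and it moves the read-out beyond the scatter: an at least 7.4-fold higher number from compound 3 to compound 4 (0.86 log units; beyond the scatter). Compound 4 gives a limit, not a number, so the full size of this step stays unread: the limit of > 100000 nM in this assay, at which 1 of the 4 values shown sits. Compound 1 also carries (tert-butyl)carbonyl and gives 18900 nM, but it differs from compound 4 in more than one place, so the step holds only on the core of compound 3. Open, going by these compounds, is how the read-out runs between methyl and tert-butyl on this carbonyl carbon; ethyl or isopropyl there would show it.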